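The compounds below may be only part of what the source reports. "The series", "measured", "known", "first", "only" and "open" are said of these compounds alone.

Compound 1 `CCOC(=O)C1=Cc2ccccc2OC1(OCc1cn(-c2cccc(OC)c2)nn1)C(F)(F)F`: in a functional assay on MCF7 cells (Homo sapiens) for inhibition, read by MTT assay, with a stated time of 24 h (on this read-out lower numbers stand for stronger inhibition and higher numbers for weaker inhibition), compound 1 gives > 150000 nM, a limit of the assay.
Compound 2 `CCOC(=O)C1=Cc2ccccc2OC1(OCc1cn(CC(=O)Nc2ccc(C)cc2)nn1)C(F)(F)F`: in this assay compound 2 gives > 150000 nM, again a limit.
Compound 3 `CCCCCCCCn1cc(COC2(C(F)(F)F)Oc3ccccc3C=C2C(=O)OCC)nn1`: in this assay compound 3 gives > 150000 nM, also a limit.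

Compound 3 therefore stands at the limit, and the same is true of the two other measured compounds, as the limit of > 150000 nM in this assay, at which 3 of the 3 values shown sit, records. The three steps among them, a step that the two limits leave unreadable from compound 1 to compound 2, a step that the two limits leave unreadable from compound 1 to compound 3 and a step that the two limits leave unreadable from compound 2 to compound 3, are all unreadable for that reason: two limits give no size and no direction.

Compound 4 `CCOC(=O)C1=Cc2ccccc2OC1(OCc1cn(CC(=O)Nc2ccccc2Br)nn1)C(F)(F)F` differs from compound 3 by (2-bromophenyl)carbamoyl in place of heptyl on a saturated chain carbon bound to an aromatic nitrogen. Of the measured steps, the one that bears most closely on this change is the step from compound 2 to compound 3, which exchanges a carbamoyl for a chain at the same place, and it is unreadable. Nothing measured here points to a step beyond the scatter in either direction, and the expected outcome is that compound 4 also sits at the limit. The expected step is a step that the limit leaves unreadable from compound 3 to compound 4. Compound 4 is estimated at 200000 nM, with a range from 80000 nM to 600000 nM.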

Compound 4, half-maximal inhibitory concentration: > 150000 nM
Compound 4: only a limit was reported; the forecaster's own chance of this, stated with the estimate: 80%; the middle value lies beyond the limit too.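

No step from compound 1, compound 2 or compound 3 to compound 4 can be read, since all four compounds end at the same limit, which gives neither size nor direction: the limit of > 150000 nM in this assay, at which 4 of the 4 values shown sit.

The compounds shown leave open how strongly any of them inhibits in this assay, and whether the group on the aromatic nitrogen matters at all.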